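From compound 3 to compound 4: a methoxy added

This account rests on a few compounds, and the source may have more. Where it says the series, first, only, none or still open, it means among the compounds named here.

Measured in a physicochemical assay for solubility, with a stated time of 3 days, at pH 2; a lower number here means a less soluble compound, a higher number a more soluble compound:
- compound 1 `CN1CCC(Oc2ccc(-c3nc4cc(C(N)=O)ccc4[nH]3)cc2)CC1`: > 400000 nM, a limit
- compound 2 `NC(=O)c1ccc2[nH]c(-c3ccc(OCC4CCNCC4)cc3)nc2c1`: > 400000 nM, a limit
- compound 3 `NC(=O)c1ccc2[nH]c(-c3ccc(OCCC4CCCCN4Cc4ccccc4)cc3)nc2c1`: > 400000 nM, a limit

Compound 3 has no exact number, only the limit > 400000 nM. The other two compounds offer no firmer reference: the limit of > 400000 nM in this assay, at which 3 of the 3 values shown sit. Compound 4 `COc1ccc(CN2CCCCC2CCOc2ccc(-c3nc4cc(C(N)=O)ccc4[nH]3)cc2)cc1` carries one change, (methoxy in place of hydrogen on an aromatic carbon), which turns benzyl into 4-methoxybenzyl. Among the compounds with values here, the only measured step, a step that the two limits leave unreadable from compound 1 to compound 2, swaps a different group, and its size cannot be read. No measured size therefore carries over, so no clear move in either direction is expected in this assay. The expected step is a number no higher from compound 3 to compound 4 (the limit leaves the size open). For compound 4 the estimated value is 400000 nM, with an expected range from 200000 nM to 800000 nM.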

Compound 4, solubility: > 400000 nM
Compound 4 ended at the assay's limit; the forecaster's own chance of this, stated with the estimate: 85%; the middle value sits exactly at the limit.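

Compound 3 and compound 4 both give only a limit in this assay, so no step can be read between them: the limit of > 400000 nM in this assay, at which 4 of the 4 values shown sit.

The compounds shown leave open whether 4-methoxybenzyl in place of benzyl changes the read-out at all, and what exact value any of the four compounds has.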